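This account rests on a few compounds, and the source may have more. Where it says the series, first, only, none or still open, it means among the compounds named here.

Compound 1 `CCN(CC)S(=O)(=O)c1ccc(S(=O)(=O)N2CCC[C@@H](C(=O)N[C@H]3CC[C@H](OC)CC3)C2)cc1` sits at the limit of a functional assay on MIA PaCa-2 cells (Homo sapiens) for inhibition, read by MTT assay, with a stated time of 3 days (on this read-out higher numbers stand for weaker inhibition and lower numbers for stronger inhibition), where compound 1 gives > 10000 nM; this is a limit of the assay and not a number (the limit of > 10000 nM in this assay, at which 1 of the 2 values shown sits). Compound 2 `O=C([C@@H]1CCCN(S(=O)(=O)c2ccc(S(=O)(=O)C3CCC3)cc2)C1)N1CCC(F)(F)CC1` also returns only a limit in this assay, at > 3000 nM (the limit of > 3000 nM in this assay, at which 1 of the 2 values shown sits). Compound 3 `CCN(CC)S(=O)(=O)c1ccc(S(=O)(=O)N2CCC[C@@H](C(=O)N3CCOCC3)C2)cc1` differs from compound 1 in one place: morpholin-4-yl in place of (4-methoxycyclohexyl)amino on a carbonyl carbon. Going by the values given here, no measured step from compound 1 is available, so the move is judged from the limit alone. With compound 1 inactive at its limit, compound 3 is expected to remain at the limit as well, the expected step that the limit leaves unreadable from compound 1 to compound 3 being within the scatter. Compound 3 is therefore estimated at 15000 nM, with a range of 5000 nM to 50000 nM.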

Compound 3, half-maximal inhibitory concentration: > 10000 nM
Compound 3 gave a limit, no number (the forecaster's own chance of this, stated with the estimate: 85%); the middle value lies beyond the limit too.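

Going by these compounds alone, compound 1 and compound 3 both stand at a limit of this assay, so no step between them can be read. The compounds shown leave open whether exchanging (4-methoxycyclohexyl)amino for morpholin-4-yl changes inhibition at all.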